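Swapping Phenyl for Chloro on a Weakly Active Lactone Acid

The source may report more compounds than this note shows. Statements on the series, on what has been measured and on what is new or still open speak of the compounds shown alone.

Three compounds were tested in a functional assay on L1210 cells (Mus musculus) for antiproliferative activity; on this read-out lower numbers stand for stronger inhibition and higher numbers for weaker inhibition. Compound 1 `C=C(Br)C(=O)Nc1ccc2[nH]c(C(=O)O)cc2c1` gives 4300 nM. Compound 2 `C=C(Br)C(=O)Nc1ccc2oc(C(=O)NCCNC(=O)c3cc(OCC4(c5ccc(Cl)cc5)CC(=C)C(=O)O4)nn3C)cc2c1`, a far larger molecule, gives 550 nM. Compound 3 `C=C1CC(COc2cc(C(=O)O)n(C)n2)(c2ccc(-c3ccccc3)cc2)OC1=O` reaches only the limit of the assay, > 10000 nM, so for compound 3 no number is known, as the limit of > 10000 nM in this assay, at which 1 of the 3 values shown sits, shows. Compound 4 `C=C1CC(COc2cc(C(=O)O)n(C)n2)(c2ccc(Cl)cc2)OC1=O` is the untested partner of compound 3 and differs from it in one place: chloro in place of phenyl on an aromatic carbon. Going by the values given here, compound 3 reports only a limit in this assay, and no measured step shows how this swap moves the value, so no change beyond the usual scatter is expected. Compound 4 is therefore estimated at 10000 nM, with a range from 3000 nM to 40000 nM. The step of a number no higher from compound 3 to compound 4 (the limit leaves the size open) is expected to stay within the scatter.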

Compound 4, half-maximal inhibitory concentration: > 10000 nM
Compound 4: no number, only a limit (the forecaster's own chance of this, stated with the estimate: 60%); the middle value lies on the limit itself.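

Going by these compounds alone, compound 3 and compound 4 each give only a limit in this assay and so no step between them can be read: the limit of > 10000 nM in this assay, at which 2 of the 4 values shown sit.

The compounds shown leave open whether chloro in place of phenyl on an aromatic carbon changes antiproliferative activity at all.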